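This account rests on a few compounds, and the source may have more. Where it says the series, first, only, none or still open, it means among the compounds named here.

Among the measured compounds shown here, the three compounds measured so far share one core and differ only in the aryl group carried on the amine nitrogen of the six-membered ring with two nitrogens. Compound 1 `Nc1scc(CN2CCN(c3cccc(Cl)c3Cl)CC2)c1C(=O)c1ccc(Cl)cc1` gives -57% in a functional assay on CHO cells with adenosine receptor A1 (Homo sapiens) as the target, read by cAMP accumulation and immunoassay, with a stated time of 6 min, tested at 1 uM; on this read-out higher numbers stand for a weaker effect at the one concentration tested and lower numbers for a stronger effect. Compound 2 `Nc1scc(CN2CCN(c3ccccc3C(F)(F)F)CC2)c1C(=O)c1ccc(Cl)cc1` gives -39% in this assay, and compound 3 `Nc1scc(CN2CCN(c3ccc(OC(F)(F)F)cc3)CC2)c1C(=O)c1ccc(Cl)cc1` gives -51% in this assay. Compound 3 thus sits close to compound 1, the two values lying within the scatter of each other, while the step of a number 12 percentage points lower from compound 2 to compound 3 (beyond the scatter) is beyond the scatter; the step of a number 6 percentage points higher from compound 1 to compound 3 (within the scatter) is not.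

Compound 4 `Nc1scc(CN2CCN(c3ccc(F)c(Cl)c3)CC2)c1C(=O)c1ccc(Cl)cc1` has not been measured. The change from compound 3 is 3-chloro-4-fluorophenyl in place of 4-(trifluoromethoxy)phenyl on an amine nitrogen in a ring. The measured steps that bear on this position, a number 18 percentage points higher from compound 1 to compound 2 (beyond the scatter) and a number 12 percentage points lower from compound 2 to compound 3 (beyond the scatter), show that swapping the aryl group here moves this assay only modestly, and the closest case, compound 1 with its 2,3-dichlorophenyl, differs from compound 3 only within the scatter. Compound 4 is therefore expected to show a step of a number 4 percentage points lower from compound 3 to compound 4 (within the scatter), no larger than the scatter. Compound 4 is estimated at -55%, with a range from -70% to -40% in this assay.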

Compound 4, a percentage reported as activity, at one concentration (the size of the read-out at that concentration, not a potency): -60%
Beside the measured number, compound 4's estimate is 5 percentage points above it; the measured number falls inside the stated range.
By their numbers in this assay, from the lowest: compounds 4, 1 and 3 (each within the scatter of the next); then compound 2.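

In this assay the change to 3-chloro-4-fluorophenyl gives a number 9 percentage points lower from compound 3 to compound 4 (within the scatter) and, set against the 2,3-dichlorophenyl group, a number 3 percentage points lower from compound 1 to compound 4 (within the scatter), so a third aryl group at this position, with fewer heavy atoms than 4-(trifluoromethoxy)phenyl, stays level with the other two. Among the compounds shown here, only 2-(trifluoromethyl)phenyl now stands apart, with a number 21 percentage points lower from compound 2 to compound 4 (beyond the scatter), and compound 2 is the one compound separated from all the others, with the weakest effect of the four. The data given offer no explanation for why this one group differs.

The compounds shown leave open whether a phenyl ring bearing an amine or a carboxylic acid, or a plain alkyl chain in place of the aryl group, would hold these numbers. With every number taken at one concentration, they also leave open how the compounds rank in potency.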